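Nitro to methoxy on compound 3

The compounds below may be only part of what the source reports. "The series", "measured", "known", "first", "only" and "open" are said of these compounds alone.

compound 1 `COc1ccc(-c2nn(-c3ccccc3)cc2C(Nc2nc3ccccc3s2)c2c(O)ccc3ccccc23)cc1` gives 17500 nM
compound 2 `O=[N+]([O-])c1ccc(-c2nn(-c3ccccc3)cc2C(Nc2nc3ccccc3s2)c2c(O)ccc3ccccc23)cc1` gives 14700 nM
compound 3 `COc1ccc2nc(NC(c3cn(-c4ccccc4)nc3-c3ccc([N+](=O)[O-])cc3)c3c(O)ccc4ccccc34)sc2c1` gives 13300 nM

In a functional assay on MCF7 cells (Homo sapiens) for antiproliferative activity, read by MTT assay, with a stated time of 48 h (a lower number here means a stronger inhibitor, a higher number a weaker inhibitor), these three values lie within the usual scatter of one another, so compound 3 at 13300 nM cannot be ranked apart from compound 1 or compound 2. Compound 4 `COc1ccc(-c2nn(-c3ccccc3)cc2C(Nc2nc3ccc(OC)cc3s2)c2c(O)ccc3ccccc23)cc1` differs from compound 3 by methoxy in place of nitro on an aromatic carbon, para to a large group, a change from 4-nitrophenyl to 4-methoxyphenyl (methoxy in place of nitro on an aromatic carbon) with the rest of the structure kept.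

The closest evidence is the same exchange in the opposite direction, which gave a 1.2-fold lower number from compound 1 to compound 2 (0.08 log units; within the scatter) and stayed within the scatter. The other measured step, methoxy in place of hydrogen on an aromatic carbon, gave a 1.1-fold lower number from compound 2 to compound 3 (0.04 log units; within the scatter) and also stayed within the scatter. Neither step leads one to expect a change beyond the scatter in this assay, and neither sets a firm direction.

The expected step is a 1.1-fold higher number from compound 3 to compound 4 (0.05 log units; within the scatter) and remains within the scatter. Compound 4 is estimated at 15000 nM with an expected range from 9000 nM to 25000 nM in this assay.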

Compound 4, half-maximal inhibitory concentration: 41800 nM
Beside the measured number, compound 4's estimate is 2.8-fold (0.45 log units) below it; the measured number lies above the stated range.
By their numbers in this assay, from the lowest: compounds 3, 2 and 1 (each within the scatter of the next); then compound 4.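

In this assay, methoxy in place of nitro, on an aromatic carbon para to a large group, now gives a 3.1-fold higher number from compound 3 to compound 4 (0.50 log units; beyond the scatter), a step beyond the scatter that the earlier pair did not show, yet the two readings of this change cannot be firmly told apart: the same change on two cores in this assay, a 1.2-fold lower number (0.08 log units; within the scatter) from compound 1 to compound 2 and a 3.1-fold lower number (0.50 log units; beyond the scatter) from compound 4 to compound 3, 2.6-fold (0.42 log units) apart, within the scatter of two such steps. Methoxy in place of hydrogen on the other side of the molecule likewise moves the number only when the 4-methoxyphenyl is present, with a 2.4-fold higher number from compound 1 to compound 4 (0.38 log units; beyond the scatter), and the same caution holds: the same change on two cores in this assay, a 1.1-fold lower number (0.04 log units; within the scatter) from compound 2 to compound 3 and a 2.4-fold higher number (0.38 log units; beyond the scatter) from compound 1 to compound 4, 2.6-fold (0.42 log units) apart, within the scatter of two such steps. For the compounds shown here, both steps end at compound 4, the one compound carrying both methoxy groups, so both new readings rest on that single compound.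

The compounds shown hold only nitro and methoxy at this position. As far as these compounds go, how an amine or a carboxylic acid there would read in this assay stays open.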